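From a Five- to a Six-Membered Ring in Compound 4

A few compounds are considered here, and "the series" means these few. Any claim that something is new, unique, unknown or untested is made for them only; others in the source may bear on it.

Going by the values given here, compound 3 `COc1cccc(-c2c(C)n(Cc3c(F)cccc3F)c(=O)n(C[C@H](N)C3CCCC3)c2=O)c1F` gives 10 nM in an assay on HEK293 cells for binding affinity to Gonadotropin-releasing hormone receptor (Homo sapiens), read by radioligand binding (a higher number here means a weaker inhibitor, a lower number a stronger inhibitor), the lowest of the three numbers so far. Compound 2 `COc1cccc(-c2c(C)n(Cc3c(F)cccc3F)c(=O)n(C[C@H](NC(C)C)C3CCCC3)c2=O)c1F` gives 12 nM, and a 1.2-fold lower number from compound 2 to compound 3 (0.08 log units; within the scatter), so these two cannot be separated. Compound 1 `COc1cccc(-c2c(C)n(Cc3c(F)cccc3F)c(=O)n(C[C@H](N)C(C)C)c2=O)c1F` gives 51 nM; a 5.1-fold lower number from compound 1 to compound 3 (0.71 log units; beyond the scatter), and a 4.3-fold lower number from compound 1 to compound 2 (0.63 log units; beyond the scatter). Compound 4 `COc1cccc(-c2c(C)n(Cc3c(F)cccc3F)c(=O)n(C[C@H](N)C3CCCCC3)c2=O)c1F` is unmeasured and differs from compound 3 by cyclohexyl in place of cyclopentyl on a saturated chain carbon bound to an amine nitrogen and a saturated chain carbon. Among the compounds with values here, the only step bearing on this change is the modest one where a ring replaced isopropyl on the same carbon; growing that ring by one carbon is a smaller alteration, so a step within the scatter is expected, leaning slightly lower. Compound 4 is therefore estimated at 8 nM, with a range from 3 nM to 25 nM. The expected step is a 1.3-fold lower number from compound 3 to compound 4 (0.10 log units; within the scatter).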

Compound 4, inhibition constant: 6.5 nM
Compound 4: middle estimate off by 1.2-fold (0.09 log units), on the high side; the measured number falls inside the stated range.
By their numbers in this assay, from the lowest: compounds 4, 3 and 2 (each within the scatter of the next); then compound 1.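

Growing the ring on this carbon from cyclopentyl to cyclohexyl gives a 1.5-fold lower number from compound 3 to compound 4 (0.19 log units; within the scatter) in this assay, so the extra ring carbon is accepted with no readable shift. The free amine with cyclohexyl also stays level with the isopropylamino compound, with a 1.8-fold lower number from compound 2 to compound 4 (0.27 log units; within the scatter) here, and the six-membered ring keeps a clear edge over isopropyl, with a 7.8-fold lower number from compound 1 to compound 4 (0.89 log units; beyond the scatter) at this position. No measurement given here accounts for these steps. Going by these compounds, a cycloheptyl or phenyl group on this carbon remains open, as does an isopropyl group on the amine nitrogen of compound 4.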